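The source may hold more compounds than are shown below. What is called first, only, known or untested is meant among the compounds shown, and "the series" means these compounds.

Compound 1 `c1ccc2c(c1)COC(c1c[nH]c3ccccc13)N2` — in an assay on isolated protein for inhibition of Alpha glucosidase (Homo sapiens) (on this read-out higher numbers stand for weaker inhibition and lower numbers for stronger inhibition), compound 1 gives 11500 nM.
Compound 2 `Cc1[nH]c2ccccc2c1C1Nc2ccccc2CO1` — compound 2 gives 11500 nM.
Compound 3 `Clc1ccc2c(c1)NC(c1c[nH]c3ccccc13)OC2` — compound 3 gives 11500 nM.

All three compounds share the same core and differ only in one small substituent. On the numbers above compound 2 stands level with compound 1 and compound 3 in this assay; none of the three can be called stronger or weaker than another, since every step between them stays within the scatter.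

Compound 4 `Cc1ccc2c(c1)COC(c1c(C)[nH]c3ccccc13)N2` has not yet been measured. It is reached from compound 2 by one change: methyl in place of hydrogen on an aromatic carbon. The new group sits on an aromatic carbon of a six-membered aromatic ring of carbon only, part of a fused system of two rings.

Two measured steps resemble this one. Adding a methyl on an aromatic carbon gave no change at the digits printed from compound 1 to compound 2 (within the scatter), and adding a chloro on an aromatic carbon of the same six-membered ring gave no change at the digits printed from compound 1 to compound 3 (within the scatter). Both changes left the read-out where it was, so a small group placed on this ring has so far made no difference in this assay.

The step from compound 2 to compound 4 is therefore expected to be no change at the digits printed from compound 2 to compound 4 (within the scatter), with no movement beyond the scatter. For compound 4 the estimated value is 11500 nM, expected to lie between 5750 nM and 23000 nM.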

Compound 4, half-maximal inhibitory concentration: 11500 nM
Compound 4: the middle estimate sits on the measured number at the digits printed, within the range that was stated.
By their numbers in this assay, from the lowest: compounds 1, 2, 3 and 4 (each within the scatter of the next).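

In this assay, placing a methyl on an aromatic carbon of a six-membered aromatic ring of carbon only gives no change at the digits printed from compound 2 to compound 4 (within the scatter), and here the starting compound already carries a methyl of its own. The earlier steps shown here each began from the unsubstituted compound 1, so this result adds that a small group can be added to an already substituted compound, at a place both meta and para to a fused ring, without any loss of inhibition beyond the scatter. Nothing available here explains why the read-out stays put in this step.

The only groups shown so far are small ones, methyl and chloro, so it remains open whether a carboxylic acid, an amine or a longer chain such as propyl at this place would shift the read-out in either direction. Also open is whether any change to the shared core can move inhibition away from the common level of these compounds at all, since every step shown so far stays within the scatter.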